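The compounds below may be only part of what the source reports. "The series", "measured", "known", "first", "only" and "open" are said of these compounds alone.

Compound 1, `CCOC(=O)C1=C(C)NC(=S)NC1c1ccc(O)cc1`, gives > 250 ug/mL in a functional assay on NCI-H460 cells (Homo sapiens) for inhibition, read by sulforhodamine B assay, with a stated time of 48 h; on this read-out lower numbers stand for stronger inhibition of growth and higher numbers for weaker inhibition of growth.
Compound 2, `CCOC(=O)C1=C(C)NC(=S)NC1c1ccc(O)c(O)c1`, gives 31.7 ug/mL in this assay.

Compound 1 stands at the limit of > 250 ug/mL in this assay, at which 1 of the 2 values shown sits, so its entry is a limit of the assay rather than a number. The only measured step between these two compounds is an at least 7.8-fold lower number from compound 1 to compound 2 (0.89 log units; beyond the scatter), brought about by hydroxy in place of hydrogen on an aromatic carbon; since one end of that step is a limit, its true size may be larger than the figure shown.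

Compound 3, `CCOC(=O)C1=C(C)NC(=S)NC1c1ccc(F)cc1`, is not yet measured. It differs from compound 1 as follows. (fluoro in place of hydroxy on an aromatic carbon). Among the measured compounds shown here, no measured step covers the loss of a hydroxy or the entry of a fluoro on the shared core. For the measured compounds named here, the single step available shows that gaining a hydroxy lowered the number in this assay; the reverse direction, giving the hydroxy up, offers no ground to expect a lower number for compound 3, and a second limit is the likelier outcome.

Compound 3 is therefore expected to fall at about 250 ug/mL, with a range from 90 ug/mL to 600 ug/mL. The expected outcome is a number no higher from compound 1 to compound 3 (the limit leaves the size open), most probably reported only as a limit.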

Compound 3, concentration for 50% growth inhibition: 14.2 ug/mL
Estimate against measurement, compound 3: 18-fold (1.25 log units) above; the measured number lies below the stated range.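

Among the compounds shown here, the para position, on the six-membered aromatic ring of carbon only, tolerates more than the earlier compounds could show: the one step known before added a second hydroxy and kept the first, whereas here the original hydroxy itself is replaced. In this assay, fluoro in place of that hydroxy gives an at least 17-fold lower number from compound 1 to compound 3 (1.24 log units; beyond the scatter), so a group with 0 hydrogen-bond donors and 0 hydrogen-bond acceptors at this place still goes with a much lower number, and the hydroxy is not required there for growth inhibition in this cell line. The entry for compound 1 is a limit and not a number, which leaves the true size of this step open: the limit of > 250 ug/mL in this assay, at which 1 of the 3 values shown sits.

The compounds shown leave open whether the lower number follows from the hydroxy leaving or from the fluoro entering, and plain hydrogen on the same carbon would separate these two readings. They also do not tell whether fluoro is special at this place or whether other groups, such as chloro, methoxy or an amine, would go the same way on the shared core.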